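The source may hold more compounds than are shown below. What is called first, only, known or untested is meant among the compounds shown, and "the series" means these compounds.

Measured compounds:
Compound 1, `O=c1ccoc2cc(OCc3cn(Cc4ccc([N+](=O)[O-])cc4)nn3)ccc12`: > 100000 nM
Compound 2, `O=c1ccoc2cc(OCc3cn(Cc4ccccc4Br)nn3)ccc12`: > 100000 nM
Compound 3, `Cc1ccccc1Cn1cc(COc2ccc3c(=O)ccoc3c2)nn1`: > 100000 nM

Each of these three values is a limit of the assay rather than a number. In a functional assay on A549 cells (Homo sapiens) for cytotoxicity, read by MTT assay, with a stated time of 48 h (a lower number here means a stronger inhibitor, a higher number a weaker inhibitor), compound 3 therefore stands only at a limit, and the two other values shown with it are limits as well, so that compound 3 cannot be ordered against compound 1 or compound 2. The steps among the measured compounds are unreadable for the same reason: a step that the two limits leave unreadable from compound 1 to compound 2, a step that the two limits leave unreadable from compound 1 to compound 3 and a step that the two limits leave unreadable from compound 2 to compound 3 all run between two limits, because of the limit of > 100000 nM in this assay, at which 3 of the 3 values shown sit.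

Compound 4, `O=c1ccoc2cc(OCc3cn(Cc4ccc(Cl)cc4Cl)nn3)ccc12`, has not yet been measured in this assay. It differs from compound 3 in one place: 2,4-dichlorophenyl in place of 2-methylphenyl on a saturated chain carbon bound to an aromatic nitrogen. The measured steps that bear on this change are those in which the group on the saturated chain carbon bound to the aromatic nitrogen was exchanged, a step that the two limits leave unreadable from compound 1 to compound 2 and a step that the two limits leave unreadable from compound 1 to compound 3, and neither gives a readable size. With all three measured compounds at the limit, no step beyond the scatter can be expected, and the most likely outcome for compound 4 is again a limit. The step expected from compound 3 to compound 4 is a step that the limit leaves unreadable from compound 3 to compound 4. Compound 4 is accordingly estimated at 150000 nM, with a range from 40000 nM to 500000 nM.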

Compound 4, half-maximal inhibitory concentration: 5260 nM
Estimate against measurement, compound 4: 29-fold (1.46 log units) above; measured number outside the range, below it.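

In this assay compound 4 gives 5260 nM, the first number among the compounds shown, so the group on the saturated chain carbon bound to the aromatic nitrogen can carry this series to a readable value. The 2,4-dichlorophenyl group gives an at least 19-fold lower number from compound 3 to compound 4 (1.27 log units; beyond the scatter) in place of 2-methylphenyl, an at least 19-fold lower number from compound 2 to compound 4 (1.27 log units; beyond the scatter) in place of 2-bromophenyl and an at least 19-fold lower number from compound 1 to compound 4 (1.27 log units; beyond the scatter) in place of 4-nitrophenyl, which shows that the earlier exchanges at this place, whose steps cannot be read, did not exhaust what it can do. As far as these compounds go, the full size of these three steps remains unknown, because compound 1, compound 2 and compound 3 each stand at a limit: the limit of > 100000 nM in this assay, at which 3 of the 4 values shown sit.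

It remains open whether a phenyl ring with a single chlorine, or a phenyl ring with no further group, would also give a number in this assay, so the compounds shown do not tell whether both chlorines are needed. Also open, from the compounds shown here alone, is how a longer chain in place of the saturated chain carbon, or an amine on the phenyl ring, would change the value of compound 4.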